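This account rests on a few compounds, and the source may have more. Where it says the series, first, only, none or still open, it means among the compounds named here.

Working notes on the series in an ADME assay on RD cells (Homo sapiens) for cytotoxicity, read by neutral red uptake, with a stated time of 3 days; on this read-out higher numbers stand for lower toxicity in this test and lower numbers for higher toxicity in this test. Compound 1 `CN(C)c1ccc(NC(=O)c2cc(-c3ccccc3)nc3ccccc23)cc1` reads > 350000 nM, which is a limit of the assay and not a number. Compound 2 `O=C(NC1CN2CCC1CC2)c1cc(-c2ccccc2)nc2ccccc12` gives 46500 nM and compound 3 `CN(C)CCCNC(=O)c1cc(-c2ccccc2)nc2ccccc12` gives 44900 nM, so compound 3 stands level with compound 2, with a 1.0-fold lower number from compound 2 to compound 3 (0.02 log units; within the scatter).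

Compound 4 `CN(C)CCCNC(=O)c1cc(-c2cccs2)nc2ccccc12` keeps the amide-side group of compound 3 and carries thiophen-2-yl in place of phenyl on an aromatic carbon.

All measured steps change the group on the amide-type nitrogen. Two are beyond the scatter, an at least 7.5-fold lower number from compound 1 to compound 2 (0.87 log units; beyond the scatter) and an at least 7.7-fold lower number from compound 1 to compound 3 (0.89 log units; beyond the scatter), and both start from the limit. The third, between compound 2 and compound 3, is within it. None of them touches the phenyl, so they give only indirect guidance on this exchange. The group that separates compound 1 from the other two stays unchanged in compound 4, so the large steps offer no reason to expect a shift, and the anchor is compound 3 at 44900 nM.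

In this assay, no step beyond the scatter is expected, and the estimated change is a 1.1-fold lower number from compound 3 to compound 4 (0.05 log units; within the scatter). For compound 4 the estimate is 40000 nM, with an expected range of 18000 nM to 85000 nM.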

Compound 4, half-maximal cytotoxic concentration: 40500 nM
Estimate against measurement, compound 4: 1.0-fold (0.01 log units) below; the measured number falls inside the stated range.
By their numbers in this assay, from the lowest: compounds 4, 3 and 2 (each within the scatter of the next). At a limit, above all of these: compound 1.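

Within the data shown here, this is the first measured change away from the amide-type nitrogen: with 3-(dimethylamino)propyl held fixed, thiophen-2-yl in place of phenyl on an aromatic carbon next to the ring nitrogen gives a 1.1-fold lower number from compound 3 to compound 4 (0.04 log units; within the scatter) in this assay. In this one pair, a five-membered aromatic ring with 1 hetero atom and 1 hydrogen-bond acceptor replaces a six-membered aromatic ring of carbon only, and the read-out stays within the scatter. The earlier steps shown here could speak to this position only indirectly, whereas this pair gives a direct reading for this single exchange, on this amide-side group only.

On these data alone, what a pyridine ring, or a phenyl carrying an amine or a carboxylic acid, would read at this position stays open, as does the effect of a longer chain on the amide-type nitrogen. Also open is whether thiophen-2-yl would read the same alongside the amide-side group of compound 1, whose reading is a limit: the limit of > 350000 nM in this assay, at which 1 of the 4 values shown sits.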